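Replacing a Formyl Group with a Benzoylethenyl Chain

This account rests on a few compounds, and the source may have more. Where it says the series, first, only, none or still open, it means among the compounds named here.

Measured so far:
- In a functional assay on A549 cells (Homo sapiens) for cytotoxicity, read by sulforhodamine B assay, with a stated time of 48 h (on this read-out lower numbers stand for stronger inhibition and higher numbers for weaker inhibition), compound 1 `CCC(C)c1cc(/C=C/C(=O)c2ccccc2)cc2cc(C(=O)OC)c(=O)oc12` gives 10700 nM.
- In this assay compound 2 `CCOC(=O)c1cc2cc(/C=C/C(=O)c3ccc(C)cc3)cc(C(C)CC)c2oc1=O` gives 32800 nM.
- In this assay compound 3 `CCOC(=O)c1cc2cc(C=O)cc(C(C)CC)c2oc1=O` gives 147000 nM.

Compound 3 stands highest of the three numbers, that is, it is the weakest inhibitor in this set. Compound 2 lies nearest to it and compound 1 furthest from it, and both of those gaps are beyond the usual scatter of this assay.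

Compound 4 `CCOC(=O)c1cc2cc(/C=C/C(=O)c3ccccc3)cc(C(C)CC)c2oc1=O` differs from compound 3 in a single place: 2-benzoylethenyl in place of formyl on an aromatic carbon. Among the measured compounds shown here, no direct step between measured compounds is available for this change, so the expectation rests on the other two compounds, which both carry a 2-benzoylethenyl group on the shared core. Compound 1 differs from compound 4 only in its methyl ester, and compound 2 carries an additional methyl group on the aromatic ring of that chain. Because compound 1 gives 10700 nM and compound 2 gives 32800 nM, both far below the number of compound 3, the change is expected to lower the number substantially, well beyond the scatter: a 9.2-fold lower number from compound 3 to compound 4 (0.96 log units; beyond the scatter). Compound 4 is therefore estimated at 16000 nM, with a range from 6000 nM to 45000 nM.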

Compound 4, half-maximal inhibitory concentration: 12900 nM
Compound 4: the middle estimate sits 1.2-fold (0.09 log units) above what was measured; low and high end bracket the measured number.
By their numbers in this assay, from the lowest: compounds 1 and 4 (each within the scatter of the next); then compound 2; then compound 3.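

In this assay the exchange of formyl for 2-benzoylethenyl on this aromatic carbon now stands as a direct step, an 11-fold lower number from compound 3 to compound 4 (1.06 log units; beyond the scatter) on the shared core, so the size of this change no longer has to be inferred from compounds that differ elsewhere as well. The chain also proves sensitive to a small alteration on its aromatic ring, where hydrogen in place of methyl gives a 2.5-fold lower number from compound 2 to compound 4 (0.41 log units; beyond the scatter) and shows that the methyl group of compound 2 is not a neutral addition, while the ester behaves differently, with a 1.2-fold higher number from compound 1 to compound 4 (0.08 log units; within the scatter) showing that the methyl and ethyl esters cannot be told apart in this read-out. No measurement given here explains why the chain, the ring methyl or the ester have these effects.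

As far as these compounds go, it remains open which part of the 2-benzoylethenyl group accounts for the large step, for example whether a saturated chain without the double bond or one without the carbonyl would do the same. Also unresolved is whether a methoxy group or a chlorine on the aromatic ring of the chain would act as the methyl does, and whether a carboxylic acid in place of the ester would leave the number unchanged.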